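This account rests on a few compounds, and the source may have more. Where it says the series, first, only, none or still open, it means among the compounds named here.

Measured compounds:
compound 1, `O=C(N[C@@H]1CCNC1)c1cc(-c2ccc(NS(=O)(=O)c3cccc(Cl)c3Cl)cc2)nc2[nH]ncc12`: < 1 nM in an assay for inhibition of serine/threonine-protein kinase Sgk1 (Homo sapiens), with stated times of 30 min and 60 min, in the presence of a further agent that is not named here; on this read-out higher numbers stand for weaker inhibition and lower numbers for stronger inhibition
compound 2, `CC(C)N1CC[C@H](NC(=O)c2cc(-c3ccc(NS(=O)(=O)c4cccc(Cl)c4Cl)cc3)nc3[nH]ncc23)C1`: 38 nM in this assay
compound 3, `O=C(NC1CCN(CC2CC2)C1)c1cc(-c2ccc(NS(=O)(=O)c3cccc(Cl)c3Cl)cc2)nc2[nH]ncc12`: 35 nM in this assay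

The value given for compound 1 is a limit of the assay, not a number, as stated at the limit of < 1 nM in this assay, at which 1 of the 3 values shown sits. Among the two numbers that are known, compound 2 and compound 3 stand within the usual scatter of each other, with a 1.1-fold lower number from compound 2 to compound 3 (0.04 log units; within the scatter). Compound 4, `NC(=O)c1cc(-c2ccc(NS(=O)(=O)c3cccc(Cl)c3Cl)cc2)nc2[nH]ncc12`, has not yet been measured. It differs from compound 2 by a single change, (hydrogen in place of 1-isopropylpyrrolidin-3-yl on an amide-type nitrogen). Among the compounds with values here, no measured step covers the loss of the whole pyrrolidine ring, so the bearing of the known steps is indirect. They do show that this amide-type nitrogen is a sensitive place: an at least 38-fold higher number from compound 1 to compound 2 (1.57 log units; beyond the scatter) and an at least 35-fold higher number from compound 1 to compound 3 (1.54 log units; beyond the scatter), both large, whereas the exchange of one alkyl group for another in a 1.1-fold lower number from compound 2 to compound 3 (0.04 log units; within the scatter) stayed within the scatter. A further large move is therefore considered possible, and the estimate for compound 4 is 150 nM, with a range from 30 nM to 1000 nM, which corresponds to an expected step of a 3.9-fold higher number from compound 2 to compound 4 (0.60 log units; beyond the scatter).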

Compound 4, half-maximal inhibitory concentration: 236 nM
Compound 4: the middle estimate sits 1.6-fold (0.20 log units) below what was measured, within the range that was stated.
By their numbers in this assay, from the lowest: compounds 3 and 2 (each within the scatter of the next); then compound 4. At a limit, below all of these: compound 1.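

In this assay, stripping the amide-type nitrogen down to its hydrogen gives a 6.2-fold higher number from compound 2 to compound 4 (0.79 log units; beyond the scatter) and a 6.7-fold higher number from compound 3 to compound 4 (0.83 log units; beyond the scatter), so the 1-isopropylpyrrolidin-3-yl and 1-(cyclopropylmethyl)pyrrolidin-3-yl groups, which had looked only like losses against pyrrolidin-3-yl, are both better than no group at all at this place. Pyrrolidin-3-yl shows a far larger step, an at least 230-fold higher number from compound 1 to compound 4 (2.37 log units; beyond the scatter), so most of what this position can contribute appears to be tied to that group. The value of compound 1 is a limit and not a number, so that step is a bound only: the limit of < 1 nM in this assay, at which 1 of the 4 values shown sits.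

From the compounds shown here alone, it remains open whether the pyrrolidine ring itself or its amine accounts for the gain over hydrogen. Going by these compounds, what a 2-aminoethyl chain or a piperidin-3-yl group would do on this nitrogen also remains open.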